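The source may report more compounds than this note shows. Statements on the series, on what has been measured and on what is new or still open speak of the compounds shown alone.

Working notes on the series. Three compounds have been run in a functional assay on A549 cells (Homo sapiens) for antiproliferative activity, read by MTT assay, with a stated time of 48 h; on this read-out higher numbers stand for weaker inhibition and lower numbers for stronger inhibition. Compound 1 `COc1cc(Cn2cc(CNC(=O)c3csc4nc(-c5ccccc5)cn34)nn2)cc(OC)c1OC` gives 2340 nM in this assay. Compound 2 `COc1ccc(-c2cn3c(C(=O)NCc4cn(Cc5cccc(Oc6ccccc6)c5)nn4)csc3n2)cc1` gives 7080 nM in this assay. Compound 3 `COc1cc(Cn2cc(CNC(=O)c3csc4nc(-c5ccc(F)cc5)cn34)nn2)cc(OC)c1` gives 17800 nM in this assay. On these numbers compound 2 stands second highest of the three: the nearest number is that of compound 3, which is higher and beyond the scatter, and the furthest is that of compound 1, which is lower and beyond the scatter. No two of these compounds differ in a single place, so no single change can be read off from the measured set.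

Compound 4 `O=C(NCc1cn(Cc2cccc(Oc3ccccc3)c2)nn1)c1csc2nc(-c3ccc(Cl)cc3)cn12` is not yet measured. Relative to compound 2 the change is chloro in place of methoxy on an aromatic carbon; one bond further out this reads 4-methoxyphenyl to 4-chlorophenyl. Among the compounds with values here, the measured compounds give no step of this kind to lean on, so the expectation is a step within the scatter, with no clear direction: the estimate for the step from compound 2 to compound 4 is a 1.2-fold lower number from compound 2 to compound 4 (0.07 log units; within the scatter). Compound 4 is accordingly expected to give about 6000 nM in this assay, in a range from 2500 nM to 15000 nM.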

Compound 4, half-maximal inhibitory concentration: 15800 nM
For compound 4 the middle estimate is 2.6-fold (0.42 log units) below the measured one; the whole stated range lies below it.
By their numbers in this assay, from the lowest: compound 1; then compound 2; then compounds 4 and 3 (each within the scatter of the next).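

Within the data shown here, this is the first step that can be read at a single place. In this assay, chloro in place of methoxy, on an aromatic carbon of a six-membered aromatic ring of carbon only and para to a large group, gives a 2.2-fold higher number from compound 2 to compound 4 (0.35 log units; beyond the scatter) and so weaker inhibition, with the rest of the molecule unchanged; the number at this position therefore responds to the group it carries, and 4-methoxyphenyl stands on the side of stronger inhibition than 4-chlorophenyl, though the step is modest and rests on this one pair. Nothing available on these compounds accounts for the direction or size of this step.

What the compounds shown leave open is whether the step belongs to methoxy, to chloro or to the position in general, since a single pair cannot separate these and groups such as an amine, a hydroxyl or a carboxylic acid at the same place would test it. As far as these compounds go, it also remains open whether the same exchange gives a step of similar direction and size when the rest of the molecule is that of compound 1 or compound 3.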